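Hydroxy for chloro on two related cores

The source may hold more compounds than are shown below. What is called first, only, known or untested is meant among the compounds shown, and "the series" means these compounds.

Compound 1 `N#Cc1c(-c2ccc(Cl)cc2)nc(SCC(=O)Nn2c(COc3ccc(Cl)cc3Cl)nc3ccccc3c2=O)[nH]c1=O`: 64.9%
Compound 2 `N#Cc1c(-c2ccc(O)cc2)nc(SCC(=O)Nn2c(COc3ccc(Cl)cc3Cl)nc3ccccc3c2=O)[nH]c1=O`: 68.4%
Compound 3 `N#Cc1c(Nc2ccc(Cl)cc2)nc(SCC(=O)Nn2c(COc3ccc(Cl)cc3Cl)nc3ccccc3c2=O)nc1-c1ccc(Cl)cc1`: 64.9%

Of the compounds shown here, three have been measured in a functional assay on the whole organism (strain albino) for inhibition, with Rattus norvegicus as the target, read by paw edema, with stated times of 1 h and 3 h, at a dose of 100 mg/kg by the oral route; on this read-out lower numbers stand for a weaker effect and higher numbers for a stronger effect at the one dose given. Compound 1 gives 64.9%, and compound 2, which carries hydroxy in place of chloro on an aromatic carbon, gives 68.4%; the step of a number 3.5 percentage points higher from compound 1 to compound 2 (within the scatter). Compound 3 is built on a different core, and the difference between the two cores is not broken down here; in this assay compound 3 gives 64.9%, level with compound 1.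

Compound 4 `N#Cc1c(Nc2ccc(O)cc2)nc(SCC(=O)Nn2c(COc3ccc(Cl)cc3Cl)nc3ccccc3c2=O)nc1-c1ccc(Cl)cc1` is not yet measured. It differs from compound 3 by hydroxy in place of chloro on an aromatic carbon, the same change as from compound 1 to compound 2. Because that step was a number 3.5 percentage points higher from compound 1 to compound 2 (within the scatter), the expected step of a number 3.1 percentage points higher from compound 3 to compound 4 (within the scatter) is of a similar small size. Compound 4 is therefore estimated to give 68%, between 58% and 78%.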

Compound 4, a percentage reported as inhibition, in the whole organism at one dose (the size of the read-out at that dose, not a potency): 91.2%
Beside the measured number, compound 4's estimate is 23.2 percentage points below it, and the stated range ends below it.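

In this assay, hydroxy in place of chloro on the aromatic carbon gives a number 26.3 percentage points higher from compound 3 to compound 4 (beyond the scatter). The change therefore does not carry over at the same size from one core to the other: the same change on two cores in this assay, a number 3.5 percentage points higher (within the scatter) from compound 1 to compound 2 and a number 26.3 percentage points higher (beyond the scatter) from compound 3 to compound 4, 22.8 percentage points apart, beyond the scatter of two such steps This rests on a single pair for each core: it shows that the size of the step differed between these two pairs, but it does not show why, nor how the change would behave on any further core.

The compounds shown leave open whether a methoxy group or an amine in the same place would also give a large step on the core of compound 3. They also leave open whether the gap between the two steps would hold at other doses.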